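Swapping hydroxyphenyl for chlorophenyl in compound 2

The source may report more compounds than this note shows. Statements on the series, on what has been measured and on what is new or still open speak of the compounds shown alone.

A small set of compounds sharing one core was tested in a functional assay on K562 cells (Homo sapiens) for cytotoxicity, read by sulforhodamine B assay; a lower number here means that less compound is tolerated, a higher number that more compound is tolerated. In this assay, compound 1 `CC1=CC[C@@H]([C@@](C)(O)CCCC(C)(C)NC=S)CC1` gives > 100000 nM, which is a limit of the assay and not a number. Compound 2 `CC1=CC[C@@H]([C@@](C)(O)CCCC(C)(C)NC(=S)N/N=C\c2ccc(O)cc2)CC1` gives > 100000 nM, which is also a limit and not a number. This places compound 2 at the limit of > 100000 nM in this assay, at which 2 of the 3 values shown sit. Compound 3 `CC1=CC[C@@H]([C@@](C)(O)CCCC(C)(C)NC(=S)N/N=C\c2ccccc2Cl)CC1`, by contrast, gives a true number of 8500 nM.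

Compound 4 `CC1=CC[C@@H]([C@@](C)(O)CCCC(C)(C)NC(=S)N/N=C\c2cccc(Cl)c2)CC1` has not yet been measured. It differs from compound 2 by 3-chlorophenyl in place of 4-hydroxyphenyl on a carbon with a double bond to nitrogen, with 3-chlorophenyl in place of 4-hydroxyphenyl on a carbon with a double bond to nitrogen. Among the measured compounds shown here, one measured step bears on this change: an at least 11-fold lower number from compound 2 to compound 3 (1.07 log units; beyond the scatter), where 4-hydroxyphenyl also leaves and 2-chlorophenyl enters. A single step is thin support, and the data hold no measurement of a 3-chlorophenyl compound, so the expectation stays loose. A large step of similar size towards a lower number is nevertheless expected. The estimated change is an at least 9.0-fold lower number from compound 2 to compound 4 (0.95 log units; beyond the scatter). For compound 4 the expected value is 11000 nM, with an estimated range from 3500 nM to 40000 nM.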

Compound 4, concentration lethal to 50% of the cells: 56300 nM
Compound 4: middle estimate off by 5.1-fold (0.71 log units), on the low side; the whole stated range lies below it.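

In this assay, the place of the chlorine on the ring matters: 3-chlorophenyl in place of 2-chlorophenyl gives a 6.6-fold higher number from compound 3 to compound 4 (0.82 log units; beyond the scatter). Compound 3 alone could have suggested that any chlorophenyl group in place of 4-hydroxyphenyl brings a large step, but the two chlorophenyl isomers do not behave alike. Compared with the hydroxyphenyl compound, the change gives an at least 1.7-fold lower number from compound 2 to compound 4 (0.24 log units; that floor lies within the scatter), and the true size of this step stays unknown because compound 2 gives a limit and not a number: the limit of > 100000 nM in this assay, at which 2 of the 4 values shown sit.

The compounds shown leave open whether other groups on this carbon, such as a bromophenyl or a methoxyphenyl group, would behave like the 2-chlorophenyl group of compound 3 or the 3-chlorophenyl group of compound 4. As far as these compounds go, all these values also come from one cell line, so it remains open whether the difference between compound 3 and compound 4 would hold in other cells.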